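The source may hold more compounds than are shown below. What is called first, only, known or untested is meant among the compounds shown, and "the series" means these compounds.

Working notes on the series.

Compound 1 `CC(C)=CCC/C(C)=C/CC/C(C)=C/CC[C@@H]1[C@@]2(C)CC/C(=N\OCc3cn(-c4ccc(F)cc4)nn3)C(C)(C)[C@@H]2CC[C@@]1(C)O` and compound 2 `CC(C)=CCC/C(C)=C/CC/C(C)=C/CC[C@@H]1[C@@]2(C)CC/C(=N\OCc3cn(-c4ccc(Cl)cc4)nn3)C(C)(C)[C@@H]2CC[C@@]1(C)O` share one core; compound 3 `CC(C)=CCC/C(C)=C/CC/C(C)=C/CC[C@@H]1[C@@]2(C)C/C(=C\c3ccc(OCc4cn(-c5ccc(F)cc5)nn4)cc3)C(=O)C(C)(C)[C@@H]2CC[C@@]1(C)O` and the not yet measured compound 4 `CC(C)=CCC/C(C)=C/CC/C(C)=C/CC[C@@H]1[C@@]2(C)C/C(=C\c3ccc(OCc4cn(-c5ccc(Cl)cc5)nn4)cc3)C(=O)C(C)(C)[C@@H]2CC[C@@]1(C)O` share another. In a functional assay on DU-145 cells (Homo sapiens) for cytotoxicity, read by MTT assay, with a stated time of 48 h (a lower number here means a stronger inhibitor, a higher number a weaker inhibitor), compound 1 gives 21600 nM and compound 2 gives 16200 nM. The change between them, (chloro in place of fluoro on an aromatic carbon), made the step of a 1.3-fold lower number from compound 1 to compound 2 (0.12 log units; within the scatter). Compound 3 gives 33600 nM in this assay; against compound 1 this lies within the scatter, against compound 2 beyond it. The difference between the core of compound 1 and the core of compound 3 is not broken down here.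

Compound 4 carries the same change on the other core: chloro in place of fluoro on an aromatic carbon. The place of the change reads the same in both pairs, so the change is taken as the same one. A step of about the size seen from compound 1 to compound 2 is expected again on this core, resting only on that single earlier pair and so held loosely. The expected step is a 1.3-fold lower number from compound 3 to compound 4 (0.11 log units; within the scatter). Compound 4 is therefore estimated at 26000 nM in this assay, with a range of 12000 nM to 55000 nM.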

Compound 4, half-maximal inhibitory concentration: 79400 nM
Beside the measured number, compound 4's estimate is 3.1-fold (0.48 log units) below it; the whole stated range lies below it.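

In this assay, chloro in place of fluoro on an aromatic carbon did not carry over unchanged from one core to the other, the new step being a 2.4-fold higher number from compound 3 to compound 4 (0.37 log units; beyond the scatter). Set beside the earlier step, the two differ: the same change on two cores in this assay, a 1.3-fold lower number (0.12 log units; within the scatter) from compound 1 to compound 2 and a 2.4-fold higher number (0.37 log units; beyond the scatter) from compound 3 to compound 4, 3.2-fold (0.50 log units) apart, beyond the scatter of two such steps. For these two cores, then, the step read on one did not hold on the other, but with a single pair on each core this gives no rule for the wider series and no reason for the gap.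

The compounds shown leave open whether other groups in the same place, such as a bromo, a methyl or a methoxy, would also give steps that differ between the two cores. Also open, going by these compounds, is whether the gap between the two steps would appear on cells other than those of this assay, and which part of the difference between the two cores goes with it.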